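Cyclopropylamide in place of dimethylamide on a fluorinated core

The compounds below may be only part of what the source reports. "The series", "measured", "known", "first", "only" and "open" are said of these compounds alone.

Measured so far:
compound 1, `NC(=O)/C=C1\CCc2c1ccc(F)c2F`: 50 mg/kg
compound 2, `CN(C)C(=O)/C=C1\CCc2c(F)cc(F)cc21`: 100 mg/kg

Of the compounds shown here, two have been tested in a functional assay on the whole organism with Mus musculus as the target, in the rotarod test; a higher number here means that more compound is needed for the effect, a lower number that less compound is needed. Compound 1 gives 50 mg/kg there, while compound 2 gives 100 mg/kg, the highest of the two numbers; the gap between compound 2 and its nearest neighbour, compound 1, lies within the scatter, so no order can be read from it. Going by the values given here, the two compounds also differ in more than one place, so no single step between measured compounds is available.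

Compound 3, `O=C(/C=C1\CCc2c(F)cc(F)cc21)NC1CC1`, keeps the core of compound 2 and carries the change (cyclopropylamino in place of dimethylamino on a carbonyl carbon). Among the compounds with values here, with no comparable step among the measured compounds, the size of this change cannot be inferred from the data. The step of a 1.4-fold lower number from compound 2 to compound 3 (0.15 log units; within the scatter) is expected to fall within the scatter or a little below it. Compound 3 is therefore estimated at 70 mg/kg, with a range from 30 mg/kg to 150 mg/kg.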

Compound 3, dose for half-maximal effect: 62 mg/kg
Compound 3: the middle estimate sits 1.1-fold (0.05 log units) above what was measured; the measured number falls inside the stated range.
By their numbers in this assay, from the lowest: compounds 1, 3 and 2 (each within the scatter of the next).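

In this assay, going by these compounds alone, the exchange of dimethylamino for cyclopropylamino on the carbonyl carbon gives a 1.6-fold lower number from compound 2 to compound 3 (0.21 log units; within the scatter) and provides the first single-place comparison. On this core, a group with a three-membered ring and an amide hydrogen can therefore stand in place of dimethylamino without a change that can be told from the scatter. No measurement shown explains this result or links it to any property of either group.

Going by these compounds, it remains open whether the number would also stay within the scatter with a longer chain, such as n-butylamino, or a larger cyclic amine, such as morpholine, on the same carbonyl carbon. On these data alone, it is equally open whether a hydroxyl group or a carboxylic acid on the cyclopropyl ring would move the number beyond it.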